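This account rests on a few compounds, and the source may have more. Where it says the series, first, only, none or still open, it means among the compounds named here.

Three compounds have been measured:
compound 1, `CC1(C)C(=O)Nc2nc(-n3nc(Cc4ccccc4F)c4ccccc43)nc(N)c21`, 3000 nM
compound 2, `Nc1nc(-n2nc(Cc3ccccc3F)c3ccccc32)nc2c1CC(=O)N2`, 160 nM
compound 3, `CCCc1nn(-c2nc(N)c3c(n2)NC(=O)C3(C)C)c2ccc(Cl)cc12`, 546000 nM

In an assay on CHO cells for activation of soluble guanylate cyclase alpha1/beta1 complex (Homo sapiens), read by cGMP accumulation (a higher number here means that more compound is needed for the effect, a lower number that less compound is needed), compound 3 stands highest of the three numbers, and its distance from each of the other two lies beyond the scatter. Compound 4, `CC1(C)C(=O)Nc2nc(-n3nc(CCCC(F)(F)F)c4cc(Cl)ccc43)nc(N)c21`, has not yet been measured in this assay and differs from compound 3 in one place: trifluoromethyl in place of hydrogen on a saturated chain carbon, three bonds along the chain from an aromatic carbon. Going by the values given here, no measured pair in this set shows that change, so its effect cannot be read from the data. A modest step toward a lower number is expected, though a result within the scatter would not be surprising. For compound 4 the step of a 2.7-fold lower number from compound 3 to compound 4 (0.44 log units; beyond the scatter) is expected in this assay. Compound 4 is therefore estimated at 200000 nM, with a range from 40000 nM to 1000000 nM.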

Compound 4, half-maximal effective concentration: 117000 nM
Compound 4: the middle estimate sits 1.7-fold (0.23 log units) above what was measured; the range from low to high includes it.
By their numbers in this assay, from the lowest: compound 2; then compound 1; then compound 4; then compound 3.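

In this assay, going by these compounds alone, going from propyl to 4,4,4-trifluorobutyl gives a 4.7-fold lower number from compound 3 to compound 4 (0.67 log units; beyond the scatter), the first reading of any change at this saturated chain position. The step is modest but beyond the scatter, so this chain end does register the trifluoromethyl group in place of hydrogen. No available measurement bears on why the number moves.

Still open, from the compounds shown here alone, is how a plain butyl chain would read in this assay, which would separate the fluorine atoms from the added chain length. An amine or a carboxylic acid at the same chain end also remains untested in the compounds shown.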